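The source may hold more compounds than are shown below. What is called first, only, known or untested is meant among the compounds shown, and "the series" means these compounds.

Among the measured compounds shown here, compound 1 `COc1ccc(S(=O)(=O)N2CCc3cccc(-c4cccnc4)c32)cc1` is the strongest inhibitor of the three compounds measured so far: in a functional assay on MKN-45 cells (Homo sapiens) for inhibition, with a stated time of 72 h (a higher number here means a weaker inhibitor, a lower number a stronger inhibitor), compound 1 gives 68.5 nM, the lowest number of the set. Compound 2 `COc1ccc(S(=O)(=O)N2CCc3cccc(-c4ccc(N(C)C)cc4)c32)cc1` gives 237 nM in this assay, and compound 3 `COc1ccc(-c2cccc3c2N(S(=O)(=O)c2ccc(OC)cc2)CC3)cc1` gives 211 nM.

Compound 4 `COc1ccc(S(=O)(=O)N2CCc3cccc(-c4cccc(F)c4)c32)cc1` differs from compound 1 in one place: 3-fluorophenyl in place of pyridin-3-yl on an aromatic carbon.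

Two of the measured steps bear on this change, since each also exchanges the pyridin-3-yl group of compound 1 for a substituted phenyl ring at the same place. Both moved in the same direction and by a similar, modest amount: a 3.5-fold higher number from compound 1 to compound 2 (0.54 log units; beyond the scatter) and a 3.1-fold higher number from compound 1 to compound 3 (0.49 log units; beyond the scatter). Compound 3 and compound 2 sit within the scatter of each other, so the nature of the group on the phenyl ring made little difference between them.

On that basis the step from compound 1 to compound 4 is expected to be a modest rise in the number, a 2.3-fold higher number from compound 1 to compound 4 (0.37 log units; beyond the scatter). Compound 4 is therefore estimated to give 160 nM in this assay, with a range from 60 nM to 420 nM.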

Compound 4, half-maximal inhibitory concentration: 84.7 nM
Estimate against measurement, compound 4: 1.9-fold (0.28 log units) above; the range from low to high includes it.
By their numbers in this assay, from the lowest: compounds 1 and 4 (each within the scatter of the next); then compounds 3 and 2 (each within the scatter of the next).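

In this assay, a ring of carbon only can take the place of pyridin-3-yl with no change beyond the scatter, a 1.2-fold higher number from compound 1 to compound 4 (0.09 log units; within the scatter), so the ring nitrogen of compound 1 is not needed at this position, and the rise seen with compound 2 and compound 3 does not come with every phenyl ring. The phenyl groups also differ among themselves, with a 2.5-fold lower number from compound 3 to compound 4 (0.40 log units; beyond the scatter) and a 2.8-fold lower number from compound 2 to compound 4 (0.45 log units; beyond the scatter), although these steps change both the group on the phenyl ring and where it sits. Nothing measured here accounts for these differences.

A 4-fluorophenyl or 3-methoxyphenyl group would help separate the effect of the group from that of its place on the phenyl ring. On these data alone, how an amine or a carboxylic acid on that ring would fare remains open.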